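Oxadiazole-imidazoline series: aryl in place of isopropyl

The source may hold more compounds than are shown below. What is called first, only, known or untested is meant among the compounds shown, and "the series" means these compounds.

Measured so far:
compound 1 `Cc1nn(Cc2nc(-c3cccc(C4=NCCN4)c3)no2)c(=O)c2ccccc12`, 23900 nM
compound 2 `CC(C)c1noc(-c2ccc(C3=NCCN3)cc2)n1`, 230 nM

In an assay for inhibition of Amine oxidase [flavin-containing] B (Homo sapiens), read by fluorescence and spectrophotometry, using microsomes, with stated times of 30 min and 20 min (a higher number here means a weaker inhibitor, a lower number a stronger inhibitor), compound 2 gives 230 nM, the lowest of the two numbers; compound 1, with its different core, gives 23900 nM, a gap well beyond the scatter. Compound 3 `Clc1cccc(-c2noc(-c3ccc(C4=NCCN4)cc3)n2)c1` differs from compound 2 by 3-chlorophenyl in place of isopropyl on an aromatic carbon. Within the data shown here, no measured pair shows this change, so its size is unknown here. The step from compound 2 to compound 3 is expected to be small, likely toward a somewhat lower number or none beyond the scatter, a 1.5-fold lower number from compound 2 to compound 3 (0.19 log units; within the scatter). For compound 3 the estimate in this assay is 150 nM, within 30 nM to 800 nM.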

Compound 3, half-maximal inhibitory concentration: 64 nM
The estimate for compound 3 lay 2.3-fold (0.37 log units) above the measured number, and the stated range covers the measured number.
By their numbers in this assay, from the lowest: compound 3; then compound 2; then compound 1.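

At this position, on an aromatic carbon of the five-membered aromatic ring, the larger 3-chlorophenyl is accepted in place of isopropyl. In this assay the change gives a 3.6-fold lower number from compound 2 to compound 3 (0.56 log units; beyond the scatter), so an added aromatic ring of carbon only does not cost inhibition here and brings a modest gain.

The compounds shown leave open whether the chlorine contributes, since plain phenyl is absent, and how an amine or a carboxylic acid on that ring would read. Nothing available accounts for the step.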